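The source may report more compounds than this note shows. Statements on the series, on what has been measured and on what is new or still open speak of the compounds shown alone.

In a functional assay on LNCaP C4-2 cells (Homo sapiens) for inhibition, read by MTT assay, with a stated time of 48 h (on this read-out lower numbers stand for stronger inhibition and higher numbers for weaker inhibition), compound 2 `c1ccc2c(C3CC(c4ccncc4)=NO3)c[nH]c2c1` gives 12800 nM, the only number shown in this set. Compound 1 `COc1ccc2c(c1)c(C1CC(c3ccncc3)=NO1)cn2Cc1ccc(Cl)cc1` reaches only a limit in this assay, > 100000 nM, which is not a number. That limit is the limit of > 100000 nM in this assay, at which 1 of the 2 values shown sits. Compound 3 `COc1ccc2[nH]cc(C3CC(c4ccncc4)=NO3)c2c1` differs from compound 2 by methoxy in place of hydrogen on an aromatic carbon. Going by the values given here, no measured step covers such a change here, so the expected step of a 1.7-fold higher number from compound 2 to compound 3 (0.24 log units; within the scatter) is modest, toward weaker inhibition, and barely beyond the scatter. Compound 3 is accordingly estimated at 22000 nM, with a range from 6000 nM to 90000 nM.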

Compound 3, half-maximal inhibitory concentration: > 100000 nM
Compound 3: a limit, no number; the forecaster's own chance of this, stated with the estimate: 25%; at least 4.5-fold (0.65 log units) between middle value and limit.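

In this assay, going by these compounds, methoxy in place of hydrogen on this aromatic carbon gives an at least 7.8-fold higher number from compound 2 to compound 3 (0.89 log units; beyond the scatter), a change that goes beyond the scatter; its full size stays unknown, as compound 3 reaches only a limit. Compound 3 thus joins compound 1 at that limit: the limit of > 100000 nM in this assay, at which 2 of the 3 values shown sit. The step from compound 1 to compound 3 cannot be read, as both values are limits. On these data alone, whether this weakening belongs to methoxy itself or to any group on this carbon stays open. A fluorine or a hydroxyl here could separate the two.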